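The compounds below may be only part of what the source reports. "The series", "measured", "known", "first", "only" and "open" are said of these compounds alone.

Working notes on the series. Compound 1 `O[C@H](c1ccccn1)[C@]1(c2cccc(OC(F)(F)F)c2)C[C@H](O)C1` and compound 2 `O[C@H](c1ccccn1)[C@]1(c2cccc(C(F)(F)F)c2)C[C@H](O)C1` share a core; in an ADME assay on liver for metabolic stability, with Liver microsome (Rattus norvegicus) as the target, read by LC-MS, using microsomes, with a stated time of 5 h (a lower number here means slower removal, a higher number faster removal of the compound), compound 1 gives 117 mL/min/kg, and compound 2 gives 183 mL/min/kg. The change between them, (trifluoromethoxy in place of trifluoromethyl on an aromatic carbon), made a step of a 1.6-fold lower number from compound 2 to compound 1 (0.19 log units; within the scatter). Compound 3 `C[C@]1(O)C[C@@](c2cccc(C(F)(F)F)c2)([C@H](O)c2ccccn2)C1` has a different core; the difference between the two cores is not broken down here. In this assay compound 3 gives 317 mL/min/kg, a number within the scatter of compound 2 and beyond the scatter of compound 1.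

Compound 4 `C[C@]1(O)C[C@@](c2cccc(OC(F)(F)F)c2)([C@H](O)c2ccccn2)C1` is not yet measured. It differs from compound 3 by trifluoromethoxy in place of trifluoromethyl on an aromatic carbon, the same change as from compound 2 to compound 1. The step expected from compound 3 to compound 4 in this assay is a 1.6-fold lower number from compound 3 to compound 4 (0.20 log units; within the scatter), set beside a 1.6-fold lower number from compound 2 to compound 1 (0.19 log units; within the scatter), and rests on that single earlier pair only. Compound 4 is thus estimated at 200 mL/min/kg, with a range from 120 mL/min/kg to 330 mL/min/kg.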

Compound 4, clearance: 200 mL/min/kg
Beside the measured number, compound 4's estimate shows no gap at the digits printed; the measured number falls inside the stated range.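

In this assay, trifluoromethoxy in place of trifluoromethyl gives a 1.6-fold lower number from compound 3 to compound 4 (0.20 log units; within the scatter), and this step matches the one on the other core: the same change on two cores in this assay, a 1.6-fold lower number (0.19 log units; within the scatter) from compound 2 to compound 1 and a 1.6-fold lower number (0.20 log units; within the scatter) from compound 3 to compound 4, 1.0-fold (0.01 log units) apart, within the scatter of two such steps

The change therefore reads the same on the core of compound 1 and the core of compound 3, as far as these two pairs go. Each step lies within the scatter, so the pairs do not show that the change itself shifts clearance, and two cores do not show that the match would hold on a further core.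

As far as these compounds go, how a nitrile or an amine in the same place on the aromatic ring would read remains open. From the compounds shown here alone, whether any such group would behave alike on both cores also remains open.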